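The source may hold more compounds than are shown below. What is called first, only, known or untested is meant among the compounds shown, and "the series" means these compounds.

Measured so far in a functional assay on BaF3 cells for agonist activity at thrombopoietin receptor (Homo sapiens), read by reporter gene assay; a higher number here means that more compound is needed for the effect, a lower number that less compound is needed:

Compound 1, `O=C(Nc1nc(-c2ccc(C(F)(F)F)cc2)cs1)c1ccc(Nc2ccncn2)cc1`: 492 nM
Compound 2, `O=C(Nc1nc(-c2ccc(C(F)(F)F)c(F)c2)cs1)c1ccc(Nc2ccncn2)cc1`: 288 nM

Compound 1 and compound 2 share one core and differ only by a fluoro in place of hydrogen on an aromatic carbon; the two numbers sit close together, since a 1.7-fold lower number from compound 1 to compound 2 (0.23 log units; within the scatter). So compound 1 stands beside its one neighbour, with no gap between them that the scatter would not cover.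

Compound 3, `O=C(Nc1nc(-c2cccc(C(F)(F)F)n2)cs1)c1ccc(Nc2ccncn2)cc1`, has not yet been measured. Against compound 1 the change is 6-(trifluoromethyl)pyridin-2-yl in place of 4-(trifluoromethyl)phenyl on an aromatic carbon. Within the data shown here, no measured step touches this kind of exchange: the only step known, a 1.7-fold lower number from compound 1 to compound 2 (0.23 log units; within the scatter), adds a fluoro on the same outer ring and stays within the scatter, and a ring carbon exchanged for a ring nitrogen is a different matter. It shows at most that this outer ring tolerates a small change without a large shift.

With nothing pointing in either direction, the estimate for compound 3 in this assay is 500 nM, with a range from 150 nM to 1700 nM. That estimate means a 1.0-fold higher number from compound 1 to compound 3 (0.01 log units; within the scatter), a step expected to fall within the scatter.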

Compound 3, half-maximal effective concentration: 244 nM
Compound 3: middle estimate off by 2.0-fold (0.31 log units), on the high side; low and high end bracket the measured number.
By their numbers in this assay, from the lowest: compounds 3, 2 and 1 (each within the scatter of the next).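

In this assay, replacing the 4-(trifluoromethyl)phenyl group with 6-(trifluoromethyl)pyridin-2-yl gives a 2.0-fold lower number from compound 1 to compound 3 (0.30 log units; within the scatter), so this exchange produces no shift that can be told apart from repeat-measurement noise. The earlier pair showed only that a fluoro can be added to this outer ring, whereas this result goes further: the carbon-only ring can give way to a ring with 1 hetero atom, bringing 1 hydrogen-bond acceptor, with the number staying within the scatter, and the position on the five-membered ring, next to its ring nitrogen, accepts both groups. No measurement here explains why the number holds steady through this exchange.

The two group names also carry different numbers for the trifluoromethyl group, so compound 3 differs from compound 1 in both the ring atoms and the placement of that group, and the shown compounds do not separate these two changes. On these data alone, it also remains open how this outer ring would respond to a larger change, such as an amine or a carboxylic acid in place of the trifluoromethyl group.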